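The compounds below may be only part of what the source reports. "The series", "measured", "known", "first", "only" and "open" are said of these compounds alone.

For the measured compounds named here, in a functional assay on HL-60 cells (Homo sapiens) for cytotoxicity, read by luminescence and CellTiter-Glo, with a stated time of 3 days (on this read-out lower numbers stand for stronger inhibition and higher numbers for weaker inhibition), compound 1 (`N#Cc1ccc(NC(=O)c2ccc(Cl)cc2O)cc1`) gives 1300 nM, the highest of the three numbers so far. Compound 2 (`O=C(Nc1ccc(C(F)(F)F)cc1)c1ccc(Cl)cc1O`) gives 630 nM and compound 3 (`O=C(Nc1ccc(Cl)c(C(F)(F)F)c1)c1cc(F)ccc1O`) gives 600 nM, two values within the scatter of each other. Compound 4 (`N#Cc1ccc(NC(=O)c2ccc(F)cc2O)cc1`) differs from compound 1 in one place: fluoro in place of chloro on an aromatic carbon, meta to a hydroxy group and para to a large group. Going by the values given here, no measured step makes this exchange. Among the compounds with values here, the only step available, a 2.1-fold lower number from compound 1 to compound 2 (0.31 log units; beyond the scatter), is modest and concerns trifluoromethyl in place of cyano, so it bears only indirectly. In this assay the expected change is small, leaning to a higher number, with no shift beyond the scatter: a 1.4-fold higher number from compound 1 to compound 4 (0.14 log units; within the scatter). Compound 4 is estimated at 1800 nM, with an expected range of 800 nM to 4000 nM.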

Compound 4, half-maximal inhibitory concentration: 1380 nM
For compound 4 the middle estimate is 1.3-fold (0.12 log units) above the measured one; low and high end bracket the measured number.
By their numbers in this assay, from the lowest: compounds 3 and 2 (each within the scatter of the next); then compounds 1 and 4 (each within the scatter of the next).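

In this assay, fluoro in place of chloro on the aromatic carbon meta to a hydroxy group and para to a large group gives a 1.1-fold higher number from compound 1 to compound 4 (0.03 log units; within the scatter) and so, on the core of compound 1, shows no shift beyond the scatter with either halogen at this position. For the compounds shown here, this is the first measured exchange at this position, the earlier step having concerned trifluoromethyl in place of cyano. No measurement at hand accounts for the result.

As far as these compounds go, whether the halogen exchange behaves alike on the core of compound 2 stays open. So does whether an amine or a methoxy group at this position would move the number beyond the scatter.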